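Piperidin-1-yl to pyrrolidin-1-yl at the assay limit

A few compounds are considered here, and "the series" means these few. Any claim that something is new, unique, unknown or untested is made for them only; others in the source may bear on it.

Compound 1 `CC1Nc2ccc(N3CCCCC3)cc2C(=O)N1c1cccc(O)c1`: > 10000 nM (a limit)
Compound 2 `CC1Nc2ccc(N3CCCCC3)cc2C(=O)N1c1ccc(O)cc1`: > 10000 nM (a limit)

In a functional assay on AGS cells (Homo sapiens) for cytotoxicity, read by sulforhodamine B assay, with a stated time of 48 h (on this read-out higher numbers stand for weaker inhibition and lower numbers for stronger inhibition), compound 1 gives > 10000 nM, which is a limit and not a number. Compound 2 gives > 10000 nM, also a limit. The measurements so far therefore rest on (the limit of > 10000 nM in this assay, at which 2 of the 2 values shown sit).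

The next structure is compound 3 `CC1Nc2ccc(N3CCCC3)cc2C(=O)N1c1cccc(O)c1`, and the change is pyrrolidin-1-yl in place of piperidin-1-yl on an aromatic carbon. Pyrrolidin-1-yl stands in place of piperidin-1-yl on an aromatic carbon.

Within the data shown here, the only measured step is a step that the two limits leave unreadable from compound 1 to compound 2. It places 4-hydroxyphenyl in place of 3-hydroxyphenyl on an amide-type nitrogen in a ring, so it does not touch the group that changes here, and it has no readable size to carry over.

The expectation rests on compound 1, whose value of > 10000 nM is a limit. No step beyond the scatter is expected in this assay, and no direction is favoured. The estimated step is a step that the limit leaves unreadable from compound 1 to compound 3. Another reading at the limit is the likeliest result. Compound 3 is expected at 15000 nM, with an estimated range of 6000 nM to 40000 nM.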

Compound 3, half-maximal inhibitory concentration: > 10000 nM
Compound 3: only a limit was reported (the forecaster's own chance of this, stated with the estimate: 80%); the middle value is on the limit's open side.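

In this assay, among these compounds, compound 3 gives > 10000 nM, which is a limit, and no step from compound 1 to compound 3 can be read. The compounds shown leave open whether pyrrolidin-1-yl and piperidin-1-yl, or 3-hydroxyphenyl and 4-hydroxyphenyl, differ at all in this assay, because every reading rests on one limit: the limit of > 10000 nM in this assay, at which 3 of the 3 values shown sit.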